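The source may hold more compounds than are shown below. What is called first, only, known or untested is meant among the compounds shown, and "the series" means these compounds.

Measured compounds in an ADME assay on HUVEC cells (Homo sapiens) for cytotoxicity, read by MTT assay, with a stated time of 72 h; a lower number here means a stronger inhibitor, a higher number a weaker inhibitor:

compound 1, `O=C(CCC(=O)OCCCCCCSc1ccc([N+](=O)[O-])c2nonc12)Nc1ccccc1F`: 840 nM
compound 2, `Cc1ccccc1NC(=O)CCC(=O)OCCCCCCSc1ccc([N+](=O)[O-])c2nonc12`: 1410 nM
compound 3, `COc1ccc(NC(=O)CCC(=O)OCCCCCCSc2ccc([N+](=O)[O-])c3nonc23)cc1`: 1590 nM

Compound 1 carries the lowest of the three numbers, but neither neighbour is set apart from it: the steps of a 1.7-fold higher number from compound 1 to compound 2 (0.22 log units; within the scatter) and a 1.9-fold higher number from compound 1 to compound 3 (0.28 log units; within the scatter) both stay within the scatter, as does a 1.1-fold higher number from compound 2 to compound 3 (0.05 log units; within the scatter). On this evidence the group on the amide-type nitrogen has not moved the read-out in this assay at all.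

Compound 4, `O=C(CCC(=O)OCCCCCCSc1ccc([N+](=O)[O-])c2nonc12)NCCN1CCCC1`, differs from compound 1 as follows: 2-(pyrrolidin-1-yl)ethyl in place of 2-fluorophenyl on an amide-type nitrogen. Within the data shown here, no measured step covers a change of this kind; the three known steps only swap one six-membered aromatic ring of carbon for another, and all three remain within the scatter. The move to 2-(pyrrolidin-1-yl)ethyl is larger than any of them, so the expectation rests on the absence of movement seen so far rather than on a matching precedent. For compound 4 a step of a 1.8-fold higher number from compound 1 to compound 4 (0.25 log units; within the scatter) is expected, i.e. nothing clearly beyond the scatter. The estimate for compound 4 in this assay is 1500 nM, with a range from 500 nM to 5000 nM.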

Compound 4, half-maximal inhibitory concentration: 6070 nM
The estimate for compound 4 lay 4.0-fold (0.61 log units) below the measured number, outside the stated range (above it).
By their numbers in this assay, from the lowest: compounds 1, 2 and 3 (each within the scatter of the next); then compound 4.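

In this assay, the group on the amide-type nitrogen does move the read-out: a 7.2-fold higher number from compound 1 to compound 4 (0.86 log units; beyond the scatter), a 4.3-fold higher number from compound 2 to compound 4 (0.63 log units; beyond the scatter) and a 3.8-fold higher number from compound 3 to compound 4 (0.58 log units; beyond the scatter) all lie beyond the scatter, whereas swaps among the three aromatic groups did not. The position therefore does not tolerate every group equally, and the change that registers here replaces a six-membered aromatic ring of carbon with 2-(pyrrolidin-1-yl)ethyl. No measurement at hand accounts for this step.

The compounds shown leave open whether the step follows the loss of the aromatic ring or the arrival of the amine-bearing chain. A benzyl group, a plain hexyl chain or a carboxylic acid-bearing chain on the same nitrogen would help separate these two readings.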